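A few compounds are considered here, and "the series" means these few. Any claim that something is new, unique, unknown or untested is made for them only; others in the source may bear on it.

Values in an ADME assay on HepG2 cells (Homo sapiens) for cytotoxicity (a higher number here means that more compound is tolerated, a lower number that less compound is tolerated), for the measured compounds:
Compound 1 `CSc1cccc(N2C(=O)CN(c3ccc(C(F)(F)F)cc3)CC2C(=O)NC2CCCC2)c1` gives 10000 nM
Compound 2 `O=C(NC1CCCC1)C1CN(c2ccc(C(F)(F)F)cc2)CC(=O)N1c1ccc2ccsc2c1` gives 10000 nM
Compound 3 `O=C(NC1CCCC1)C1CN(c2ccc(C(F)(F)F)cc2)CC(=O)N1c1cnc2ccsc2c1` gives 30000 nM

Compound 2 stands level with compound 1 at the lower number of the three, the step being (no change at the digits printed from compound 1 to compound 2 (within the scatter)). Compound 3 lies higher (a 3.0-fold higher number from compound 2 to compound 3 (0.48 log units; beyond the scatter)).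

Compound 4 `O=C(NC1CCCC1)C1CN(c2ccccc2)CC(=O)N1c1ccc2ccsc2c1` differs from compound 2 at one place (hydrogen in place of trifluoromethyl on an aromatic carbon). This is hydrogen in place of trifluoromethyl on an aromatic carbon, so that 4-(trifluoromethyl)phenyl becomes phenyl.

Within the data shown here, no measured step touches this place. All three change the group on an amide-type nitrogen in a ring, so they bear on the new change only indirectly, as a guide to how far numbers move in this series. The two steps beyond the scatter are modest and both go upward (a 3.0-fold higher number from compound 1 to compound 3 (0.48 log units; beyond the scatter) and a 3.0-fold higher number from compound 2 to compound 3 (0.48 log units; beyond the scatter)). The data hold no direct evidence on the direction of the new change, so only a small upward lean is assumed. In this assay the expected step is modest at most (a 1.5-fold higher number from compound 2 to compound 4 (0.18 log units; within the scatter)). The estimated value for compound 4 is 15000 nM (expected range 6000 nM to 40000 nM).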

Compound 4, half-maximal cytotoxic concentration: > 50000 nM
Compound 4 was reported as a limit (the forecaster's own chance of this, stated with the estimate: 25%); middle value at least 3.3-fold (0.52 log units) away from the limit.
By their numbers in this assay, from the lowest: compounds 1 and 2 (each within the scatter of the next); then compound 3. At a limit, above all of these: compound 4.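

In this assay, among these compounds, the earlier compounds differ only in the group on an amide-type nitrogen in a ring, so the aromatic carbon para to a large group is read here for the first time: with hydrogen in place of trifluoromethyl, so that 4-(trifluoromethyl)phenyl becomes phenyl, the result is an at least 5.0-fold higher number from compound 2 to compound 4 (0.69 log units; beyond the scatter). Among the compounds shown here, with the 1-benzothiophen-6-yl group held constant, this single change moves the number further than any of the earlier steps among compounds 1, 2 and 3, which reach no more than a modest size. Compound 4 gives > 50000 nM, which is a limit of the assay and not a number, so the step has a lower bound and no fixed size: the limit of > 50000 nM in this assay, at which 1 of the 4 values shown sits.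

The compounds shown leave open whether the same change would move the number as far with a different group on the amide-type nitrogen, such as the one in compound 3; only compound 2 and compound 4 form this pair. They also leave open how a chlorine atom, a methoxy group or an amine at this place would read in this assay.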